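The source may report more compounds than this note shows. Statements on the series, on what has been measured and on what is new or still open speak of the compounds shown alone.

Of the compounds shown here, two sharing one core have been tested so far in a functional assay on T47D cells (Homo sapiens) for inhibition, read by CCK-8 assay, with a stated time of 72 h, tested at 1 uM; on this read-out lower numbers stand for less inhibition of growth and higher numbers for more inhibition of growth at the one concentration tested. Compound 1 `CN(C)C(=O)c1cc2cnc(Nc3ccc(N)cn3)nc2n1C1CCCC1` gives 18.8%. Compound 2 `CN(C)C(=O)c1cc2cnc(Nc3ccc(NC(=O)C4(C(=O)Nc5cccc(F)c5)CC4)cc3)nc2n1C1CCCC1` gives -3.2%, the lower of the two numbers, and its gap to compound 1 lies beyond the usual scatter. A value this close to zero means that hardly any inhibition of growth was seen at the one concentration tested. The two compounds differ in more than one place, so their gap cannot be tied to any single change.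

Compound 3 `CN(C)C(=O)c1cc2cnc(Nc3ccc(NC(=O)C4(C(=O)Nc5cccc(Cl)c5)CC4)cc3)nc2n1C1CCCC1` is compound 2 with one small edit: chloro in place of fluoro on an aromatic carbon. Put simply, this is chloro in place of fluoro on an aromatic carbon, turning the 3-fluorophenyl group into 3-chlorophenyl. Among the compounds with values here, no measured pair here shows what this swap does, so the expectation starts from compound 2 at -3.2% and assumes no step beyond the scatter, in either direction. The expected change is small, a number 5.2 percentage points higher from compound 2 to compound 3 (within the scatter). The estimated value for compound 3 is 2%, with an expected range of -8% to 14%.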

Compound 3, percent growth inhibition at one concentration: 39.3%
For compound 3 the middle estimate is 37.3 percentage points below the measured one; the whole stated range lies below it.
By their numbers in this assay, from the lowest: compound 2; then compound 1; then compound 3.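

In this assay, within the data shown here, chloro in place of fluoro on this aromatic carbon gives a number 42.5 percentage points higher from compound 2 to compound 3 (beyond the scatter) and this is the first measured pair here that differs in only one place. It shows that this aromatic ring, at the far end of the molecule from the shared core, is a sensitive spot in this series: exchanging a single atom, with no change in rings, hydrogen-bond donors, hydrogen-bond acceptors or net charge, separates a compound with hardly any growth inhibition from compound 3 at 39.3% in the same test. Nothing available here explains why the two halogens behave so differently.

Among these compounds, with only one pair at this position, it remains open whether the rise follows a trend or belongs to chloro alone, and a bromo, methyl, trifluoromethyl or methoxy group on the same aromatic carbon, or a plain unsubstituted phenyl ring, would help to settle that. From the compounds shown here alone, the comparison also rests on a single concentration in a single cell line, so how compound 3 behaves at other concentrations or in other cells stays unknown.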